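The compounds below may be only part of what the source reports. "The series", "measured", "known", "first", "only" and "open" are said of these compounds alone.

Of the compounds shown here, three have been measured so far. Compound 1 `COc1cc(-c2cc(/C=C/C(=O)c3ccc(N)cc3)[nH]n2)cc(OC)c1OC` gives 102% in a functional assay on Malme-3M cells (Homo sapiens) for cytotoxicity, read by sulforhodamine B assay, with a stated time of 48 h, tested at 0.1 uM; on this read-out lower numbers stand for a stronger effect and higher numbers for a weaker effect at the one concentration tested. Compound 2 `COc1ccc(C(=O)/C=C/c2cc(-c3cc(OC)c(OC)c(OC)c3)n[nH]2)cc1OC` gives 92% in this assay, and compound 3 `COc1ccc(C(=O)/C=C/c2cc(-c3cc(OC)c(OC)c(OC)c3)n[nH]2)cc1` gives 91%. The step of a number 10 percentage points lower from compound 1 to compound 2 (within the scatter) and the step of a number 1 percentage points lower from compound 2 to compound 3 (within the scatter) both stay inside the usual scatter, while a number 11 percentage points lower from compound 1 to compound 3 (beyond the scatter) just crosses it. Compound 1 and compound 2 differ only at the carbonyl carbon, where the difference reads (4-aminophenyl in place of 3,4-dimethoxyphenyl on a carbonyl carbon). Compound 2 and compound 3 differ by hydrogen in place of methoxy on an aromatic carbon, and that change moved the read-out by a number 1 percentage points lower from compound 2 to compound 3 (within the scatter), in effect nothing.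

Compound 4 `COc1ccc(-c2cc(/C=C/C(=O)c3ccc(N)cc3)[nH]n2)cc1OC` has not yet been measured. Relative to compound 1 it carries the difference (hydrogen in place of methoxy on an aromatic carbon). Within the data shown here, this is the same kind of change as the one from compound 2 to compound 3, but not the same: in compound 4 the carbon that loses the methoxy group is ortho to a methoxy group, meta to a large group and also meta to a methoxy group, whereas in compound 3 it is ortho to a methoxy group and meta to a large group only, and the ring concerned is on the other side of the shared core.

Because the comparable step a number 1 percentage points lower from compound 2 to compound 3 (within the scatter) was flat, the step from compound 1 to compound 4 is expected to be about a number 3 percentage points lower from compound 1 to compound 4 (within the scatter) in this assay. Among the measured compounds shown here, compound 4 is therefore estimated at 99%, with a likely range of 86% to 112%, resting on compound 1 at 102% and on the single flat precedent; with one precedent only, the range is kept wide.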

Compound 4, a percentage reported as activity, at one concentration (the size of the read-out at that concentration, not a potency): 108%
Compound 4: middle estimate off by 9 percentage points, on the low side; the range from low to high includes it.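

On the core of compound 1, hydrogen in place of methoxy on an aromatic carbon gives a number 6 percentage points higher from compound 1 to compound 4 (within the scatter) in this assay. Set beside the same change on the other core, this step shows that the change leaves the read-out flat on both cores, and the two steps do not differ: the same change on two cores in this assay, a number 1 percentage points lower (within the scatter) from compound 2 to compound 3 and a number 6 percentage points higher (within the scatter) from compound 1 to compound 4, 7 percentage points apart, within the scatter of two such steps This does not establish a general rule for carrying the change across the series, since it rests on two pairs at the one concentration tested, the carbon losing the methoxy group has a different surrounding in each pair, and neither pair shows how the change behaves on a core with a much lower number in this read-out.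

The compounds shown leave open whether ethoxy, hydroxy or fluorine in place of the same methoxy group would read like hydrogen on these cores. Also open, from the compounds shown here alone, is whether the flat step would hold with a carboxylic acid or a morpholine in place of the amino group of compound 1.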